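Methoxy in Place of Methyl on a Shared Core

The source may report more compounds than this note shows. Statements on the series, on what has been measured and on what is new or still open speak of the compounds shown alone.

Of the compounds shown here, three have so far been measured in a functional assay on A549 cells (Homo sapiens) for cytotoxicity, read by MTT assay, with a stated time of 72 h; on this read-out higher numbers stand for weaker inhibition and lower numbers for stronger inhibition. Compound 1, `COc1ccc(-c2ccc(C(=O)Nc3ccc(Oc4ccnc5[nH]ccc45)cc3)nc2)cc1`, reaches only the limit of the assay, giving > 10000 nM in this assay. Compound 2, `CCc1ccc(-c2ccc(C(=O)Nc3ccc(Oc4ccnc5[nH]ccc45)cc3)nc2)cc1`, likewise gives only the limit > 10000 nM. Compound 3, `Cc1ccc(-c2ccnc(C(=O)Nc3ccc(Oc4ccnc5[nH]ccc45)cc3)c2)cc1`, also gives only the limit > 10000 nM. Compound 3 therefore stands where every value shown stands, at the limit of > 10000 nM in this assay, at which 3 of the 3 values shown sit, with no number beneath it.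

Compound 4, `COc1ccc(-c2ccnc(C(=O)Nc3ccc(Oc4ccnc5[nH]ccc45)cc3)c2)cc1`, differs from compound 3 in one place: methoxy in place of methyl on an aromatic carbon. Among the measured compounds shown here, only one measured step joins two compounds that differ in a single place, a step that the two limits leave unreadable from compound 1 to compound 2, and it lies on a different arrangement of the shared core; both its ends are limits, so its size cannot be read. For the measured compounds named here, no measured step tells how a methoxy compares with a methyl on this core. What the data do show is that every compound tested reaches only the limit, and compound 4 is expected to behave the same way. The step that the limit leaves unreadable from compound 3 to compound 4 is accordingly expected to be no change beyond the scatter. For compound 4 the estimate is 15000 nM, with a range from 5000 nM to 50000 nM.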

Compound 4, half-maximal inhibitory concentration: 6970 nM
Compound 4: middle estimate off by 2.2-fold (0.33 log units), on the high side; measured number inside the range.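

On this arrangement of the shared core, going from 4-methylphenyl to 4-methoxyphenyl moves the read-out off the limit, giving an at least 1.4-fold lower number from compound 3 to compound 4 (0.15 log units; that floor lies within the scatter) in this assay. Compound 3 holds only a limit, so this figure is a floor: the real step may be larger, but the size that can be read does not by itself go beyond the usual scatter. Even so, this place on the ring, para to a large group, is the first to show a change that gives a number, and compound 4 stands apart from the other compounds, which offer only a limit: the limit of > 10000 nM in this assay, at which 3 of the 4 values shown sit.

What the compounds shown leave open is whether another group at this same place, such as a hydroxyl, an amine or a longer chain like ethoxy, would bring the number lower still or return it to the limit. Also open, going by these compounds, is whether methoxy has any readable effect on the other arrangement of the core, where compound 1 and compound 2 both rest at the limit and the step between them cannot be read.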